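The compounds below may be only part of what the source reports. "The series", "measured", "known", "first", "only" and "open" are said of these compounds alone.

In a functional assay on A549 cells (Homo sapiens) for antiproliferative activity, read by MTT assay, with a stated time of 72 h (a lower number here means a stronger inhibitor, a higher number a weaker inhibitor), compound 1 (`COc1ccccc1/C=C/C(=O)/C=C/c1nc(C)c(C)nc1C`) gives 3200 nM and compound 2 (`COc1ccc(/C=C/C(=O)/C=C/c2nc(C)c(C)nc2C)cc1`) gives 3500 nM, so these two values lie within the scatter of each other. Compound 3 (`COc1ccc(/C=C/C(=O)/C=C/c2nc(C)c(C)nc2C)c(OC)c1`) differs from compound 2 by methoxy in place of hydrogen on an aromatic carbon, with methoxy in place of hydrogen on an aromatic carbon, ortho to a large group and meta to a methoxy group. Among the measured compounds shown here, no measured step yet shows the effect of such a change, and no shift beyond the scatter is expected in this assay, in either direction. The expected change is a 1.2-fold lower number from compound 2 to compound 3 (0.07 log units; within the scatter). Compound 3 is estimated at 3000 nM, within an expected range of 1200 nM to 7000 nM.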

Compound 3, half-maximal inhibitory concentration: 3070 nM
Compound 3: middle estimate off by 1.0-fold (0.01 log units), on the low side; the range from low to high includes it.
By their numbers in this assay, from the lowest: compounds 3, 1 and 2 (each within the scatter of the next).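

Methoxy in place of hydrogen on an aromatic carbon, ortho to a large group and meta to a methoxy group, gives no shift beyond the scatter in this assay, with a 1.1-fold lower number from compound 2 to compound 3 (0.06 log units; within the scatter) and a 1.0-fold lower number from compound 1 to compound 3 (0.02 log units; within the scatter). Among the compounds shown here, this position therefore accepts a second methoxy group with the number unchanged within the scatter, which the earlier compounds, each with a single methoxy group, could not show. Nothing at hand explains this result.

The compounds shown leave open whether an amine, a carboxylic acid or a longer chain at this position would move the number beyond the scatter.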